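A few compounds are considered here, and "the series" means these few. Any claim that something is new, unique, unknown or untested is made for them only; others in the source may bear on it.

Compounds measured so far:
- compound 1, `CNc1nc(SC)nc2c1ncn2[C@@H]1C[C@@H](O)[C@H](CO)O1`
- compound 2, `CN(C)c1nc(Br)nc2c1ncn2[C@@H]1C[C@@H](O)[C@H](CO)O1`
- compound 3, `CSc1nc(N(C)C)c2ncn([C@@H]3C[C@@H](O)[C@H](CO)O3)c2n1`

In a functional assay on U-937 cells (Homo sapiens) (a lower number here means a stronger inhibitor, a higher number a weaker inhibitor), compound 1 gives only a limit, > 300 uM (the limit of > 300 uM in this assay, at which 1 of the 3 values shown sits). Compound 2 gives 164 uM in this assay. Compound 3 gives 126 uM in this assay. Of the two numbers that are not limits, compound 2 carries the higher one; its nearest neighbour is compound 3, with a change of a 1.3-fold lower number from compound 2 to compound 3 (0.11 log units; within the scatter), a methylsulfanyl in place of bromo on an aromatic carbon.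

Compound 4, `CNc1nc(Br)nc2c1ncn2[C@@H]1C[C@@H](O)[C@H](CO)O1`, is the next compound. It differs from compound 2 by hydrogen in place of methyl on a nitrogen on an aromatic ring. For the measured compounds named here, one measured step bears on this change, run in the opposite direction: an at least 2.3-fold lower number from compound 1 to compound 3 (0.37 log units; beyond the scatter), where a methyl was added to the ring nitrogen on the methylsulfanyl core. Since compound 1 gave only a limit, that step is known only as a lower bound. Taking the methyl off again on the bromo core is therefore expected to raise the number, by a 2.4-fold higher number from compound 2 to compound 4 (0.39 log units; beyond the scatter), and may well push compound 4 to the limit of this assay. Compound 4 is thus expected to give about 400 uM in this assay, with a range of 150 uM to 1500 uM.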

Compound 4, concentration for 50% inhibition: 140 uM
The estimate for compound 4 lay 2.9-fold (0.46 log units) above the measured number, and the stated range ends above it.
By their numbers in this assay, from the lowest: compounds 3, 4 and 2 (each within the scatter of the next). At a limit, above all of these: compound 1.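

In this assay, the change from dimethylamino to methylamino with bromo on the aromatic carbon amounts to a 1.2-fold lower number from compound 2 to compound 4 (0.07 log units; within the scatter), so the clear step seen with methylsulfanyl does not carry over to this core: the same change on two cores in this assay, an at least 2.3-fold lower number (0.37 log units; beyond the scatter) from compound 1 to compound 3 and a 1.2-fold higher number (0.07 log units; within the scatter) from compound 4 to compound 2, at least 2.7-fold (0.44 log units) apart, beyond the scatter of two such steps. Bromo in place of methylsulfanyl, with methylamino on the ring, gives an at least 2.1-fold lower number from compound 1 to compound 4 (0.33 log units; beyond the scatter), yet the same exchange with dimethylamino stays within the scatter, so the two places do not act independently: the same change on two cores in this assay, a 1.3-fold lower number (0.11 log units; within the scatter) from compound 2 to compound 3 and an at least 2.1-fold higher number (0.33 log units; beyond the scatter) from compound 4 to compound 1, at least 2.7-fold (0.44 log units) apart, beyond the scatter of two such steps. Compound 1 gives only a limit, > 300 uM, so both of these gaps are known only as lower bounds.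

From the compounds shown here alone, what remains open is whether an ethyl group or a longer chain on that nitrogen, or a free amino group, would behave as methyl does. Going by these compounds, whether chloro in place of bromo would fit the same picture also stays open.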